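Hydrogen for Methyl on the Amine of Compound 2

A few compounds are considered here, and "the series" means these few. Any claim that something is new, unique, unknown or untested is made for them only; others in the source may bear on it.

Compound 1 `CN(C)Cc1nnc(-c2ccco2)n1-c1ccc(Cl)cc1C(=O)c1ccccc1`: in a functional assay on the whole organism (strain CF-1) for positive allosteric modulation, with Mus musculus as the target (a higher number here means that more compound is needed for the effect, a lower number that less compound is needed), compound 1 gives 25 mg/kg.
Compound 2 `Cc1nnc(CN(C)C)n1-c1ccc(Cl)cc1C(=O)c1ccccc1`: compound 2 gives 1.1 mg/kg.
Compound 3 `Cc1nnc(CN(C)C)n1-c1ccccc1C(=O)c1ccccc1Cl`: compound 3 reaches only a limit of this assay, > 100 mg/kg.

Among the two numbers, compound 2 stands lowest; its nearest neighbour is compound 1, with a 23-fold lower number from compound 1 to compound 2 (1.36 log units; beyond the scatter). Compound 3 sits at the limit of > 100 mg/kg in this assay, at which 1 of the 3 values shown sits. Compound 4 `CNCc1nnc(C)n1-c1ccc(Cl)cc1C(=O)c1ccccc1` differs from compound 2 by hydrogen in place of methyl on an amine nitrogen. Among the measured compounds shown here, the only measured step, a 23-fold lower number from compound 1 to compound 2 (1.36 log units; beyond the scatter), lies at another place and does not bear on the amine. For the measured compounds named here, no measured step therefore guides this change, and a step within the scatter is expected, a 1.8-fold higher number from compound 2 to compound 4 (0.26 log units; within the scatter). Compound 4 is estimated at 2 mg/kg, with a range from 0.5 mg/kg to 8 mg/kg.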

Compound 4, dose for half-maximal effect: 2 mg/kg
Compound 4: the middle estimate sits on the measured number at the digits printed; low and high end bracket the measured number.
By their numbers in this assay, from the lowest: compounds 2 and 4 (each within the scatter of the next); then compound 1. At a limit, above all of these: compound 3.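

In this assay the step of a 1.8-fold higher number from compound 2 to compound 4 (0.26 log units; within the scatter) shows that this place on the amine nitrogen accepts hydrogen in place of methyl without leaving the scatter. Among the compounds shown here, it is the first measured step at this nitrogen, since the earlier step lay at another place, and it shows that dimethylamino and methylamino read alike here. Nothing measured in this set gives a cause for this result. Still open, on these data alone, is how the primary amine, or an ethyl group on the same nitrogen, would read in this assay.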